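The source may hold more compounds than are shown below. What is called first, only, known or untested is meant among the compounds shown, and "the series" means these compounds.

Measured compounds:
- compound 1 `Cc1cc(NCc2ccccn2)n2ncc(-c3ccc(N(C)C)cc3)c2n1`: < 5000 nM
- compound 2 `Cc1cc(NCc2nccn2C)n2nc(C)cc2n1`: 182000 nM

Of the compounds shown here, two have been measured in a physicochemical assay for solubility, read by HPLC, using the shake flask method, measured as kinetic solubility, with a stated time of 2 h, at pH 7.4; a higher number here means a more soluble compound, a lower number a less soluble compound. Compound 1 `Cc1cc(NCc2ccccn2)n2ncc(-c3ccc(N(C)C)cc3)c2n1` gives < 5000 nM, which is a limit of this assay rather than a number. Compound 2 `Cc1cc(NCc2nccn2C)n2nc(C)cc2n1` gives 182000 nM in this assay. Among the measured compounds shown here, the two compounds differ in several places at once, so no single step between them is counted, and the pair shows only that one value sits at a limit while the other is a number well within the measured range; as the limit of < 5000 nM in this assay, at which 1 of the 2 values shown sits, records, one of the two values sits at that limit.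

The step followed here goes from compound 1 to compound 3 `Cc1cc(NCc2ccccn2)n2ncc(-c3cccc(N)c3)c2n1`, which has not yet been measured in this assay. The change is 3-aminophenyl in place of 4-(dimethylamino)phenyl on an aromatic carbon. Compound 3 is expected to sit a little higher than the limit reached by compound 1, with the step from compound 1 to compound 3 estimated as a modest rise, an at least 1.6-fold higher number from compound 1 to compound 3 (0.20 log units; that floor lies within the scatter). Compound 3 is therefore estimated at 8000 nM, within a range from 2000 nM to 40000 nM.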

Compound 3, solubility: 160000 nM
For compound 3 the middle estimate is 20-fold (1.30 log units) below the measured one; the measured number lies above the stated range.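

Among the compounds shown here, the earlier pair differed in several places at once, so this is the only single change that can be read so far. In this assay, putting 3-aminophenyl in place of 4-(dimethylamino)phenyl on an aromatic carbon of the five-membered aromatic ring gives an at least 32-fold higher number from compound 1 to compound 3 (1.50 log units; beyond the scatter), which shows that the number depends strongly on the group at this position while the rest of compound 1 stays the same. The size of this step is only a floor, because the value of compound 1 is a limit and not a number: the limit of < 5000 nM in this assay, at which 1 of the 3 values shown sits.

The two groups differ both in where the nitrogen group stands on the phenyl ring, as their names show, and in whether it is an amino or a dimethylamino group, and the compounds shown cannot separate these two differences. As far as these compounds go, how a plain phenyl ring or a phenyl ring carrying a carboxylic acid would read at this position also remains open, as does whether a step of this size would appear with a group other than the pyridine-bearing side chain of compound 1 elsewhere on the shared core.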